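The source may hold more compounds than are shown below. What is called first, only, known or untested is meant among the compounds shown, and "the series" means these compounds.

In a physicochemical assay for inhibition, with a stated time of 1 h (on this read-out lower numbers stand for stronger inhibition and higher numbers for weaker inhibition), compound 1 (`COc1ccccc1NC(=S)NNC(=O)CSCc1cc(C(C)(C)C)c(O)c(C(C)(C)C)c1`) gives 60500 nM and stands within the scatter of compound 2 (`COc1ccccc1-n1c(S)nnc1CSCc1cc(C(C)(C)C)c(O)c(C(C)(C)C)c1`) at 38900 nM while compound 3 (`COc1ccccc1Nc1nnc(CSCc2cc(C(C)(C)C)c(O)c(C(C)(C)C)c2)s1`) at 13200 nM gives a lower number than compound 1 by more than the scatter. Compound 4 (`COc1ccc(NC(=S)NNC(=O)CSCc2cc(C(C)(C)C)c(O)c(C(C)(C)C)c2)cc1`) has the same atoms as compound 1 joined differently (4-methoxyphenyl in place of 2-methoxyphenyl on an amide-type nitrogen) with 4-methoxyphenyl in place of 2-methoxyphenyl on an amide-type nitrogen. For the measured compounds named here, no measured pair shows this change. In this assay no step beyond the scatter is therefore expected, and the expectation stays near compound 1 at 60500 nM as its starting point. The expected change is a 1.2-fold lower number from compound 1 to compound 4 (0.08 log units; within the scatter) by this estimate. For compound 4 the estimated value is 50000 nM with an expected range from 22000 nM to 110000 nM on this read-out.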

Compound 4, half-maximal inhibitory concentration: 30100 nM
Estimate against measurement, compound 4: 1.7-fold (0.22 log units) above; low and high end bracket the measured number.
By their numbers in this assay, from the lowest: compound 3; then compounds 4, 2 and 1 (each within the scatter of the next).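

In this assay, for the compounds shown here, placing 4-methoxyphenyl in place of 2-methoxyphenyl on an amide-type nitrogen gives the only direct reading at this position, and the step is a 2.0-fold lower number from compound 1 to compound 4 (0.30 log units; within the scatter) and so does not separate the two compounds. This exchange of methoxyphenyl groups therefore registers no change beyond the scatter on the core of compound 1. No available measurement bears on the reason for this result. Still open, going by these compounds, is whether an amine or a carboxylic acid in place of the methoxy group on this phenyl would move the number beyond the scatter. Also open, on these data alone, is whether the same exchange would do so on the core of compound 3.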